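A few compounds are considered here, and "the series" means these few. Any claim that something is new, unique, unknown or untested is made for them only; others in the source may bear on it.

In an in vitro ADME assay on microsomes from liver (Homo sapiens) for metabolic stability, using NADPH (a higher number here means faster removal of the compound, a lower number slower removal), compound 3 (`COc1ccc(OC(F)(F)F)cc1Cn1c(C(=O)NCC2(CO)CC2)cc2cc(C#N)ccc21`) gives 139 mL.min-1.g-1 and lies within the scatter of the two other measured compounds. Compound 1 (`COc1ccc(OC(F)(F)F)cc1Cn1c(C(=O)NCC(C)(C)CO)cc2cc(C#N)ccc21`) gives 69 mL.min-1.g-1 and compound 2 (`Cc1ccc(Cl)cc1Cn1c(C(=O)NCC(C)(C)CO)cc2cc(C#N)ccc21`) gives 119 mL.min-1.g-1 in the same this assay measurement. Compound 4 (`COc1ccc(C(C)(C)C)cc1Cn1c(C(=O)NCC2(CO)CC2)cc2cc(C#N)ccc21`) has not yet been measured. The change from compound 3 to compound 4 is tert-butyl in place of trifluoromethoxy on an aromatic carbon and it puts tert-butyl in place of trifluoromethoxy on an aromatic carbon, para to a methoxy group. Among the measured compounds shown here, only one measured step links compounds that differ in one place: a 2.0-fold higher number from compound 1 to compound 3 (0.30 log units; within the scatter) with 1-(hydroxymethyl)cyclopropyl in place of 1-(hydroxymethyl)-1-methylethyl. That step lies within the scatter and concerns the chain on the amide nitrogen, not the aromatic carbon that changes here. Compound 2 carries neither trifluoromethoxy nor tert-butyl, and its value is also within the scatter of that of compound 3. For the measured compounds named here, no measured pair isolates the exchange of these two groups, so the data give no direct size for it. The expected step is a 1.3-fold higher number from compound 3 to compound 4 (0.11 log units; within the scatter) and it would stay within the scatter, with a slight upward lean as a cautious guess. For compound 4 the estimated value is 180 mL.min-1.g-1 with an expected range from 85 mL.min-1.g-1 to 380 mL.min-1.g-1 as the likely span of a measurement.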

Compound 4, intrinsic clearance in microsomes: 188 mL.min-1.g-1
Compound 4: middle estimate off by 1.0-fold (0.02 log units), on the low side; the range from low to high includes it.
By their numbers in this assay, from the lowest: compounds 1, 2, 3 and 4 (each within the scatter of the next, the first and the last beyond it).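

In this assay, the exchange of trifluoromethoxy for tert-butyl on an aromatic carbon para to a methoxy group gives a 1.4-fold higher number from compound 3 to compound 4 (0.13 log units; within the scatter), the only step shown that isolates a change at this position. It shows that, with the core and the 1-(hydroxymethyl)cyclopropyl chain on the amide nitrogen held constant, this replacement of a fluorine-bearing group with an all-carbon group does not move the intrinsic clearance in microsomes beyond the scatter, so the two groups cannot be told apart in this read-out. No accompanying evidence explains this outcome.

A single pair cannot show whether the same exchange would also stay within the scatter with the 1-(hydroxymethyl)-1-methylethyl chain of compound 1, or whether the result holds for other groups at this position. On these data alone, it also remains open whether a carboxylic acid or an amine on this aromatic carbon, in place of trifluoromethoxy or tert-butyl, would give a step beyond the scatter in this assay.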